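Removing the 4-bromobenzoyl group: expected cytotoxicity of compound 4

This account rests on a few compounds, and the source may have more. Where it says the series, first, only, none or still open, it means among the compounds named here.

Measured compounds:
- compound 1 `CC(C)N(Cc1cccc(OCCCCCC(=O)O)c1)C(=O)c1ccc(-c2cccc(N(C)C)c2)cc1`: > 26000 nM
- compound 2 `CCOC(=O)CCCCCOc1cccc(CN(C(=O)c2ccc(-c3cccnc3)cc2)C(C)C)c1`: > 26000 nM
- compound 3 `CCCN(Cc1ccc(OCCCCCC(=O)OCC)cc1)C(=O)c1ccc(Br)cc1`: > 26000 nM

All three measured values in an ADME assay on BJ cells (Homo sapiens) for cytotoxicity, read by CellTiter-Glo and resazurin assay, with a stated time of 72 h (a higher number here means that more compound is needed for the effect, a lower number that less compound is needed), are limits rather than numbers. For compound 3 the result in this assay is only the limit > 26000 nM. Compound 1 likewise sits at a limit. Compound 2 also sits at a limit. For the measured compounds named here, this is summed up by the limit of > 26000 nM in this assay, at which 3 of the 3 values shown sit; no measured step between two compounds exists here, so nothing about the effect of any single change can be read off.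

Compound 4 `CCCNCc1ccc(OCCCCCC(=O)OCC)cc1` is not yet measured. It differs from compound 3 in one place: hydrogen in place of (4-bromophenyl)carbonyl on an amine nitrogen. With every measured value sitting at a limit, the only reasonable expectation for the step from compound 3 to compound 4 is no change that could be seen, which would again leave compound 4 at the limit; this expectation is written as a step that the limit leaves unreadable from compound 3 to compound 4. For compound 4 the value expected in this assay is therefore 40000 nM, within the range 15000 nM to 120000 nM, most likely reported only as a limit.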

Compound 4, half-maximal effective concentration: > 26000 nM
Compound 4 was reported as a limit; the forecaster's own chance of this, stated with the estimate: 85%; the middle value is on the limit's open side.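

In this assay, compound 4 gives > 26000 nM, which is a limit. For the compounds shown here, compound 3 also sits at a limit, so no step from compound 3 to compound 4 can be read. The compounds shown leave open at what concentration any of them would reach the effect, and whether any single structural change would shift it: the limit of > 26000 nM in this assay, at which 4 of the 4 values shown sit.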